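The source may hold more compounds than are shown below. What is called first, only, known or untested is meant among the compounds shown, and "the series" means these compounds.

Measured in a functional assay on NCI-H1299 cells (Homo sapiens) for cytotoxicity, read by resazurin assay, with a stated time of 72 h; on this read-out lower numbers stand for stronger inhibition and higher numbers for weaker inhibition:
- compound 1 `COc1cc(/C=C/C(=O)OCCCCCCO[N+](=O)[O-])ccc1O`: > 50000 nM, a limit of the assay
- compound 2 `O=C(/C=C/c1ccc(OCCCCCO[N+](=O)[O-])c(O)c1)OCCCCCO[N+](=O)[O-]`: > 50000 nM, a limit of the assay
- compound 3 `COc1cc(/C=C/C(=O)OCCCCCO[N+](=O)[O-])ccc1O`: 20800 nM

Compound 3 is the only one of the three with an actual number, since the other two entries are limits. The next compound to be tested is compound 4 `COc1cc(/C=C/C(=O)OCCCCCO[N+](=O)[O-])ccc1OCCCCCO[N+](=O)[O-]`, which follows from compound 3 by one change: 5-(nitrooxy)pentyl in place of hydrogen on an oxygen on an aromatic ring. In words, 5-(nitrooxy)pentyl takes the place of hydrogen on an oxygen on an aromatic ring.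

For the measured compounds named here, only one measured step is available, an at least 2.4-fold lower number from compound 1 to compound 3 (0.38 log units; beyond the scatter). It concerns the chain and not the oxygen on the aromatic ring, so it bears on the present change only indirectly. It does show that a small alteration of a nitrooxy chain can move a compound to the limit in this assay. Compound 2 also carries a 5-(nitrooxy)pentyl group on an oxygen on an aromatic ring, and it reads > 50000 nM, which is a limit. That limit is a wider pattern in this small set: the limit of > 50000 nM in this assay, at which 2 of the 3 values shown sit.

A modest move towards weaker inhibition is therefore expected, and the expected step is a 1.7-fold higher number from compound 3 to compound 4 (0.23 log units; within the scatter). Compound 4 is estimated at 35000 nM, with an expected range from 12000 nM to 90000 nM.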

Compound 4, half-maximal inhibitory concentration: > 50000 nM
Compound 4 gave a limit, no number; the forecaster's own chance of this, stated with the estimate: 50%; middle value at least 1.4-fold (0.15 log units) from the limit.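

In this assay, putting 5-(nitrooxy)pentyl in place of hydrogen on an oxygen on an aromatic ring gives an at least 2.4-fold higher number from compound 3 to compound 4 (0.38 log units; beyond the scatter), so this change, taken alone, costs compound 3 its measurable value. For the compounds shown here, compound 2 carries the same group but differs from compound 3 in more than one place, which means that this step is the first reading of the change by itself. Keeping the hydroxy is not sufficient for a number, since compound 1 has it and still reads as a limit, and the set is now dominated by that ceiling: the limit of > 50000 nM in this assay, at which 3 of the 4 values shown sit.

As far as these compounds go, how far the change weakens inhibition stays open, since the entry for compound 4 is a limit and the step from compound 2 to compound 4 cannot be read, which leaves the effect of methyl in place of hydrogen on the other oxygen unresolved. Also open, from the compounds shown here alone, is whether a smaller group on this oxygen, such as ethyl or acetyl, or a chain ending in an amine or a carboxylic acid instead of nitrooxy, would keep a measurable value.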